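A few compounds are considered here, and "the series" means these few. Any claim that something is new, unique, unknown or untested is made for them only; others in the source may bear on it.

Measured so far, in a functional assay on HepG2 cells (Homo sapiens) for cytotoxicity, read by MTT assay, with a stated time of 2 days; on this read-out higher numbers stand for weaker inhibition and lower numbers for stronger inhibition:

Compound 1, `O=[N+]([O-])c1ccc2c(c1)/C(=N\O)C(c1c[nH]c3ccc([N+](=O)[O-])cc13)=N2`, gives 8250 nM.
Compound 2, `Cc1ccc(CO/N=C2/C(c3c[nH]c4ccccc34)=Nc3ccccc32)cc1`, gives 19100 nM.
Compound 3, `Clc1cccc(CO/N=C2/C(c3c[nH]c4ccc(Br)cc34)=Nc3ccc(Br)cc32)c1`, gives 13300 nM.

Compound 2 gives the highest number of the three in this assay, but its gap to compound 3 lies within the usual scatter, so the two cannot be told apart. Compound 1 gives a number beyond the scatter lower than compound 2, which stands for stronger inhibition of the cells. Compound 4, `Fc1ccc(CO/N=C2/C(c3c[nH]c4ccccc34)=Nc3ccccc32)c(Cl)c1`, has not yet been measured. It differs from compound 2 in one place: 2-chloro-4-fluorophenyl in place of 4-methylphenyl on a saturated chain carbon bound to an oxygen on an unsaturated carbon. Going by the values given here, no pair of measured compounds shows what this kind of swap does in this assay, since compound 1 and compound 3 each differ from compound 2 in more than one place. With nothing to guide the direction, the expectation for the step from compound 2 to compound 4 is a 1.2-fold lower number from compound 2 to compound 4 (0.08 log units; within the scatter), which is no change beyond the scatter. Compound 4 is therefore estimated at 16000 nM, within a range from 6000 nM to 45000 nM.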

Compound 4, half-maximal inhibitory concentration: 25500 nM
The estimate for compound 4 lay 1.6-fold (0.20 log units) below the measured number, and the stated range covers the measured number.
By their numbers in this assay, from the lowest: compounds 1, 3, 2 and 4 (each within the scatter of the next, the first and the last beyond it).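

In this assay, going by these compounds alone, the swap from 4-methylbenzyl to 2-chloro-4-fluorobenzyl gives a 1.3-fold higher number from compound 2 to compound 4 (0.13 log units; within the scatter) and is the first direct reading of a change at this place. The two compounds therefore cannot be told apart, so in this one pair, exchanging a methyl-bearing ring for one bearing chlorine and fluorine does not shift the number beyond the usual scatter. No measurement at hand explains this result.

Still open, as far as these compounds go, is whether a different kind of group at this place, such as a carboxylic acid, an amine or a longer chain, would move the number beyond the scatter. Also open, from the compounds shown here alone, is whether the same swap would give a similarly small step on a core carrying bromine, like that of compound 3.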